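Moving a methoxy group one more time

The source may hold more compounds than are shown below. What is called first, only, known or untested is meant among the compounds shown, and "the series" means these compounds.

In a functional assay on HeLa cells (Homo sapiens) for antiproliferative activity, read by MTT assay, with a stated time of 48 h (a higher number here means a weaker inhibitor, a lower number a stronger inhibitor), compound 1 `COc1ccccc1N1CCN(Cn2nc(-c3ccc4c(c3)OCCO4)oc2=S)CC1` gives > 50000 nM as a limit of the assay, not as a number. Among the measured compounds shown here, compound 2 `COc1cccc(N2CCN(Cn3nc(-c4ccc5c(c4)OCCO5)oc3=S)CC2)c1` gives 18000 nM as the only true number so far, so no other measured number exists to rank it against. Compound 3 `COc1ccc(N2CCN(Cn3nc(-c4ccc5c(c4)OCCO5)oc3=S)CC2)cc1` has the same atoms as compound 2, joined differently: 4-methoxyphenyl stands in place of 3-methoxyphenyl on an amine nitrogen in a ring (4-methoxyphenyl in place of 3-methoxyphenyl on an amine nitrogen in a ring). For the measured compounds named here, one measured step bears on this change. It is an at least 2.7-fold lower number from compound 1 to compound 2 (0.44 log units; beyond the scatter) with 3-methoxyphenyl in place of 2-methoxyphenyl on that same nitrogen, so where the methoxy group sits can matter in this series. That single step rests on a limit, however, and it gives no direction for the new change. No step beyond the scatter is therefore expected in this assay for now. Put as a step, the estimate is a 1.4-fold higher number from compound 2 to compound 3 (0.14 log units; within the scatter) for the moment. For compound 3 the estimated value is 25000 nM with an expected range from 9000 nM to 50000 nM as the likely span.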

Compound 3, half-maximal inhibitory concentration: > 50000 nM
Compound 3 ended at the assay's limit; the forecaster's own chance of this, stated with the estimate: 25%; at least 2.0-fold (0.30 log units) between middle value and limit.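

Replacing 3-methoxyphenyl with 4-methoxyphenyl on the amine nitrogen in the ring gives an at least 2.7-fold higher number from compound 2 to compound 3 (0.44 log units; beyond the scatter) in this assay, so this change, like the earlier one involving 2-methoxyphenyl, separates the two compounds by more than the usual scatter. Compound 2 now has a measured step to each of the other two compounds, and among these three compounds only the 3-methoxyphenyl group gives a true number rather than a limit, something the first step alone could not show. The step between compound 1 and compound 3 cannot be read, and the data in this small set are bounded at the top: the limit of > 50000 nM in this assay, at which 2 of the 3 values shown sit.

Going by these compounds, how far the 2-methoxyphenyl and 4-methoxyphenyl compounds lie from each other stays unknown, as both values are limits and neither can be ranked against the other. Also open, on these data alone, is whether a hydroxyl or an ethoxy group in place of the methoxy group of the 3-methoxyphenyl ring would give a lower number than compound 2, which gives 18000 nM.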